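This account rests on a few compounds, and the source may have more. Where it says the series, first, only, none or still open, it means among the compounds named here.

Measured in a functional assay on DU-145 cells (Homo sapiens) for inhibition, read by trypan blue exclusion, with a stated time of 96 h; a lower number here means a stronger inhibitor of growth, a higher number a weaker inhibitor of growth:
- compound 1 `Cc1ccc(S(=O)(=O)/C(=C/c2ccc(Cl)cc2)C(=O)c2ccc(Cl)cc2)cc1`: 1000 nM
- compound 2 `COc1ccc(C(=O)/C(=C\c2ccc(Cl)cc2)S(=O)(=O)c2ccc(Cl)cc2)cc1`: 4000 nM
- compound 3 `O=C(O)c1ccc(C(=O)/C(=C\c2ccc(F)c([N+](=O)[O-])c2)SCc2ccc(F)cc2)cc1`: 1000 nM

Among these three, compound 2 has the highest number, so it is the weakest inhibitor of growth. Its gap to each of the other two lies beyond the usual scatter, and compound 1 and compound 3 show the same value.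

The next compound to be tested is compound 4 `O=C(/C(=C\c1ccc(Cl)cc1)S(=O)(=O)c1ccc(Cl)cc1)c1ccc(Cl)cc1`. It is compound 2 with a single change: chloro in place of methoxy on an aromatic carbon. In words, this is chloro in place of methoxy on an aromatic carbon, or 4-methoxyphenyl becoming 4-chlorophenyl.

For the measured compounds named here, no measured pair shows this change on its own, so the expectation rests on thin evidence. The closest guide is compound 1, which also carries 4-chlorophenyl at that place and gives 1000 nM, although it differs elsewhere as well. A modest move toward a lower number therefore seems likely, possibly not much beyond the scatter. The expected step of a 2.7-fold lower number from compound 2 to compound 4 (0.43 log units; beyond the scatter) is only an estimate. For compound 4 the estimated value is 1500 nM, with an expected range from 500 nM to 5000 nM.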

Compound 4, concentration for 50% growth inhibition: 25000 nM
Estimate against measurement, compound 4: 17-fold (1.22 log units) below, outside the stated range (above it).
By their numbers in this assay, from the lowest: compounds 1 and 3 (each within the scatter of the next); then compound 2; then compound 4.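

Chloro in place of methoxy on an aromatic carbon gives a weaker inhibitor of growth in this assay, with a 6.3-fold higher number from compound 2 to compound 4 (0.80 log units; beyond the scatter), so 4-chlorophenyl brings no gain over 4-methoxyphenyl at this position. Chloro in place of methyl on an aromatic carbon, at a different place in the molecule, moves the same way, with a 25-fold higher number from compound 1 to compound 4 (1.40 log units; beyond the scatter), and neither single-change pair goes against this direction. The data shown offer nothing that explains these steps.

The compounds shown leave open how an amine, a hydroxyl group or a longer chain such as ethoxy would behave at the position that held methoxy. They also leave open whether the direction seen with chloro would hold on a core other than that of compound 4.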